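The compounds below may be only part of what the source reports. "The series", "measured", "known", "first", "only" and "open" are said of these compounds alone.

Measured compounds:
Compound 1, `Cc1nc(S(C)(=O)=O)ccc1Oc1ncnc(OC2CCN(C(=O)SC3CC3)CC2)c1F`: 80%
Compound 2, `Cc1nc(S(C)(=O)=O)ccc1Oc1ncnc(OC2CCN(C(=O)C(C)(F)F)CC2)c1F`: 87%
Compound 3, `Cc1nc(S(C)(=O)=O)ccc1Oc1ncnc(OC2CCN(C(=O)C3(F)CCC3)CC2)c1F`: 91%

In a functional assay on isolated protein for inhibition of Glucose-dependent insulinotropic receptor (Rattus norvegicus), read by HTRF and cAMP accumulation (a higher number here means a larger maximal response, a lower number a smaller maximal response), compound 3 gives the largest of the three numbers, yet its gap to compound 2 lies within the scatter, and only its gap to compound 1 is beyond it. The unmeasured compound 4, `Cc1nc(S(C)(=O)=O)ccc1Oc1ncnc(OC2CCN(C(=O)c3nc(C(C)(C)F)no3)CC2)c1F`, differs from compound 3 only at the carbonyl carbon: a group of 9 heavy atoms (5 carbon, 2 nitrogen, 1 oxygen, 1 fluorine; one five-membered aromatic ring with 3 hetero atoms) in place of a group of 5 heavy atoms (4 carbon, 1 fluorine; one four-membered non-aromatic ring of carbon only), on a carbonyl carbon.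

All three measured steps vary the group on that same carbonyl carbon: a number 7 percentage points higher from compound 1 to compound 2 (within the scatter), a number 11 percentage points higher from compound 1 to compound 3 (beyond the scatter) and a number 4 percentage points higher from compound 2 to compound 3 (within the scatter). Across these replacements the maximal response moved little, with only one step beyond the scatter. For the measured compounds named here, the group entering in compound 4 is, however, of a kind not yet covered here, an aromatic ring bearing acceptors, so the earlier steps carry limited weight. Compound 4 is therefore expected to show a number 6 percentage points lower from compound 3 to compound 4 (within the scatter), a change not beyond the scatter. The maximal response of compound 4 in this assay is estimated at 85%, within a range from 70% to 96%.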

Compound 4, largest response reached (reported as efficacy), in percent of the reference or control that the assay uses: 84%
Estimate against measurement, compound 4: 1 percentage points above; the range from low to high includes it.
By their numbers in this assay, from the lowest: compounds 1, 4, 2 and 3 (each within the scatter of the next, the first and the last beyond it).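

In this assay, a five-membered aromatic ring with 3 hetero atoms and 3 hydrogen-bond acceptors stays close to all three earlier groups: a number 7 percentage points lower from compound 3 to compound 4 (within the scatter) and a number 3 percentage points lower from compound 2 to compound 4 (within the scatter) and a number 4 percentage points higher from compound 1 to compound 4 (within the scatter). The position on a carbonyl carbon whose other neighbours are amide-type nitrogen in a ring therefore accommodates this group of 9 heavy atoms with no step beyond the scatter, which the earlier non-aromatic groups of 4 and 5 heavy atoms could not show. Nothing available here explains this closeness.

The compounds shown leave open whether the same position would keep its maximal response with an amine or a carboxylic acid in the group on the carbonyl carbon. They also leave open how a simple methyl group on the aromatic ring would compare with the fluorine-bearing branch of compound 4.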